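Fluoro for methoxy on the pendant aryl: compound 4

The compounds below may be only part of what the source reports. "The series", "measured", "known", "first", "only" and "open" are said of these compounds alone.

Three compounds share one core and differ only in the aryl group attached to it. Compound 1 `COc1ccc(-c2cn3ccnc3c(-c3ccc4ncn(C5CCCCC5)c4c3)n2)cc1` gives 77.8% in a functional assay on SW-620 cells (Homo sapiens) for inhibition, read by sulforhodamine B assay, with a stated time of 48 h, tested at 10 uM; on this read-out higher numbers stand for more inhibition at the one concentration tested (going by the name of the read-out) and lower numbers for less inhibition. Compound 2 `Clc1ccc(-c2cn3ccnc3c(-c3ccc4ncn(C5CCCCC5)c4c3)n2)cc1` gives 14%, and compound 3 `COc1ccccc1-c1cn2ccnc2c(-c2ccc3ncn(C4CCCCC4)c3c2)n1` gives 3.4%, the lowest of the three numbers. Every step runs downward from compound 1: a number 63.8 percentage points lower from compound 1 to compound 2 (beyond the scatter), a number 74.4 percentage points lower from compound 1 to compound 3 (beyond the scatter), and between the two compounds with the lower numbers a number 10.6 percentage points lower from compound 2 to compound 3 (beyond the scatter).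

Compound 4 `Fc1ccccc1-c1cn2ccnc2c(-c2ccc3ncn(C4CCCCC4)c3c2)n1` differs from compound 3 by fluoro in place of methoxy on an aromatic carbon. Going by the values given here, no measured step swaps methoxy for fluoro. Among the compounds with values here, the only step that removes a methoxy is a number 63.8 percentage points lower from compound 1 to compound 2 (beyond the scatter), and that concerns chloro on 4-methoxyphenyl rather than anything on 2-methoxyphenyl; the two steps that lead to compound 3 describe moving from 4-methoxyphenyl or 4-chlorophenyl to 2-methoxyphenyl, not a change of the group itself. Compound 3 already sits close to the bottom of the scale, so a further fall can hardly be large, and nothing among the three compounds supports a rise back toward compound 1. The expected step is therefore a number 4.6 percentage points higher from compound 3 to compound 4 (within the scatter), within the scatter. For compound 4 the estimated value in this assay is 8%, with a range from 0% to 30%.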

Compound 4, a percentage reported as inhibition, at one concentration (the size of the read-out at that concentration, not a potency): 9.53%
Compound 4: middle estimate off by 1.5 percentage points, on the low side, within the range that was stated.
By their numbers in this assay, from the lowest: compounds 3, 4 and 2 (each within the scatter of the next, the first and the last beyond it); then compound 1.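

In this assay the change from 2-methoxyphenyl to 2-fluorophenyl, on a carbon ortho to a large group, gives a number 6.1 percentage points higher from compound 3 to compound 4 (within the scatter) and so does not separate the two compounds. Going by these compounds alone, this is the first direct reading of methoxy against fluoro at this place, and it shows that the smaller fluoro does not bring the number back toward compound 1: the comparison with 4-chlorophenyl gives a number 4.5 percentage points lower from compound 2 to compound 4 (within the scatter) and the comparison with 4-methoxyphenyl gives a number 68.3 percentage points lower from compound 1 to compound 4 (beyond the scatter) as its outcome. Compound 1 thus remains the only one of the four set apart by steps beyond the scatter, and no measurement at hand explains why the numbers of compound 2, compound 3 and compound 4 stay low.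

On these data alone, whether fluoro in place of the methoxy of compound 1 would give a number like that of compound 1 or like that of compound 2 stays open, and so does whether the reading from compound 3 to compound 4 holds on that aryl group. Also open, as far as these compounds go, is whether an amine, a hydroxyl or a longer ether chain in place of that methoxy would keep the number of compound 1.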